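The compounds below may be only part of what the source reports. "The series", "measured", "known", "first", "only" and "open" are said of these compounds alone.

In a functional assay on MCF7 cells (Homo sapiens) for inhibition, read by MTT assay, with a stated time of 72 h (a lower number here means a stronger inhibitor, a higher number a weaker inhibitor), the measured compounds stand as follows.
Compound 1, `Cc1ccc(NC(=O)C2CCN(C/C=C/c3ccccc3)CC2)cc1`, gives 30000 nM.
Compound 2, `CC(C)c1ccc(NC(=O)C2CCN(C/C=C/c3ccccc3)CC2)cc1`, gives 9100 nM.
Compound 3, `COc1ccccc1NC(=O)C1CCN(C/C=C/c2ccccc2)CC1`, gives > 100000 nM, which is a limit of the assay and not a number.

Compound 3 therefore sits at the weak end of the set, known only through (the limit of > 100000 nM in this assay, at which 1 of the 3 values shown sits). Two measured steps lead to it: an at least 3.3-fold higher number from compound 1 to compound 3 (0.52 log units; beyond the scatter) and an at least 10-fold higher number from compound 2 to compound 3 (1.04 log units; beyond the scatter), both showing that the 2-methoxyphenyl on the amide-type nitrogen carries the highest number here, while a 3.3-fold lower number from compound 1 to compound 2 (0.52 log units; beyond the scatter) shows a gain within the phenyl series. Compound 4, `O=C(Nc1ccccn1)C1CCN(C/C=C/c2ccccc2)CC1`, differs from compound 3 in one place: pyridin-2-yl in place of 2-methoxyphenyl on an amide-type nitrogen. Within the data shown here, no measured step introduces a pyridin-2-yl, so the expectation rests on the two steps that remove the 2-methoxyphenyl, each beyond the scatter and each downward in number. Compound 4 is therefore expected to return to a measurable number, and its estimated step is an at least 2.0-fold lower number from compound 3 to compound 4 (0.30 log units; that floor lies within the scatter). Compound 4 is estimated at 50000 nM, within a range from 10000 nM to 200000 nM.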

Compound 4, half-maximal inhibitory concentration: 67200 nM
Estimate against measurement, compound 4: 1.3-fold (0.13 log units) below, and the stated range covers the measured number.
By their numbers in this assay, from the lowest: compound 2; then compound 1; then compound 4. At a limit, above all of these: compound 3.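

In this assay, pyridin-2-yl on the amide-type nitrogen brings a ring with a hetero atom to this place and gives a measurable number where 2-methoxyphenyl gave only a limit, with an at least 1.4-fold lower number from compound 3 to compound 4 (0.17 log units; that floor lies within the scatter). That step is only a floor, and its size cannot be fixed, since compound 3 is known only as a limit: the limit of > 100000 nM in this assay, at which 1 of the 4 values shown sits. Pyridin-2-yl nevertheless falls short of both 4-methylphenyl and 4-isopropylphenyl at this place, with a 2.2-fold higher number from compound 1 to compound 4 (0.35 log units; beyond the scatter) and a 7.4-fold higher number from compound 2 to compound 4 (0.87 log units; beyond the scatter).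

The compounds shown leave open whether the ring nitrogen's place matters, as pyridin-3-yl or pyridin-4-yl would show, and whether the loss with 2-methoxyphenyl belongs to the methoxy group or to where it sits, as 4-methoxyphenyl would show. They also leave open what a 4-chlorophenyl or a 4-aminophenyl would do on the same nitrogen.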